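Phenyl for Naphthalen-1-yl in a Quinolone Oxadiazole Series

A few compounds are considered here, and "the series" means these few. Any claim that something is new, unique, unknown or untested is made for them only; others in the source may bear on it.

Measured compounds:
compound 1 `O=c1c(-c2nnc(-c3ccc(Nc4ccccc4)cc3)o2)cn(C2CC2)c2cc(N3CCNCC3)c(F)cc12`: 52 ug/mL
compound 2 `CCn1cc(-c2nnc(COc3cccc4ccccc34)o2)c(=O)c2cc(F)c(N3CCNCC3)cc21`: 127 ug/mL
compound 3 `O=c1c(-c2nnc(COc3ccc4ccccc4c3)o2)cn(C2CC2)c2cc(N3CCNCC3)c(F)cc12`: 16 ug/mL

Three compounds share a common core and differ in the group carried on the oxadiazole ring. In a functional assay on A549 cells (Homo sapiens) for cytotoxicity, read by MTT assay (on this read-out lower numbers stand for stronger inhibition and higher numbers for weaker inhibition), compound 2 gives 127 ug/mL, the highest number of the three. Its nearest neighbour on the scale is compound 1, which gives 52 ug/mL, a gap beyond the scatter, and the furthest from compound 2 is compound 3, which gives 16 ug/mL, also beyond the scatter. No pair among these three differs in one place only, so none of these gaps can be attributed to a single structural change.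

Compound 4 `CCn1cc(-c2nnc(COc3ccccc3)o2)c(=O)c2cc(F)c(N3CCNCC3)cc21` has not yet been measured. It differs from compound 2 in one place: phenyl in place of naphthalen-1-yl on an oxygen on a saturated carbon. Within the data shown here, there is no measured step in this set that isolates this kind of change, so the expectation rests on the position of compound 2 alone. The step from compound 2 to compound 4 is expected to be a 1.2-fold higher number from compound 2 to compound 4 (0.07 log units; within the scatter), that is, no change beyond the scatter, with a modest lean toward a higher number. Compound 4 is therefore estimated at 150 ug/mL, within a range from 60 ug/mL to 350 ug/mL.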

Compound 4, half-maximal inhibitory concentration: 76.8 ug/mL
Compound 4: middle estimate off by 2.0-fold (0.29 log units), on the high side; the measured number falls inside the stated range.
By their numbers in this assay, from the lowest: compound 3; then compounds 1, 4 and 2 (each within the scatter of the next, the first and the last beyond it).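

In this assay, among these compounds, the exchange of naphthalen-1-yl for phenyl on an oxygen on a saturated carbon gives a 1.7-fold lower number from compound 2 to compound 4 (0.22 log units; within the scatter) and is the first step in this set that isolates a single change. The step lies within the usual scatter, so on the core of compound 2 the group can go from 10 heavy atoms to 6, and from two six-membered aromatic rings of carbon only to one, without a shift on this read-out that can be told apart from repeat-to-repeat variation. Nothing among the available data gives a reason for this result.

The compounds shown leave open whether an amine or a carboxylic acid carried on the phenyl of compound 4, or a longer chain in its place, would move the number beyond the scatter. Among the compounds shown here, this single pair is also the only reading of the change, and whether phenyl for naphthalen-1-yl stays within the scatter on the core of compound 1 remains an open question.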